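The compounds below may be only part of what the source reports. "The series", "measured", "known", "first", "only" and "open" are said of these compounds alone.

Measured so far: compound 1 `CCCc1ccc(-c2cc(OC)cc(C(=O)Nc3nn[nH]n3)n2)cc1` gives 93% in a functional assay on the whole organism with Rattus norvegicus as the target, at a dose of 3 mg/kg by the oral route; on this read-out higher numbers stand for a stronger effect at the one dose given and lower numbers for a weaker effect; compound 2 `CCCCc1ccc(-c2cc(OC)cc(C(=O)Nc3nn[nH]n3)n2)cc1` gives 61%.

Compound 2 stands lowest of the two numbers, its nearest neighbour being compound 1, which stands higher by the step of a number 32 percentage points lower from compound 1 to compound 2 (beyond the scatter). Compound 3 `COc1cc(C(=O)Nc2nn[nH]n2)nc(-c2ccc(N(C)C)cc2)c1` has not been measured. It differs from compound 2 in one place: dimethylamino in place of butyl on an aromatic carbon. For the measured compounds named here, the only measured step, a number 32 percentage points lower from compound 1 to compound 2 (beyond the scatter), concerns a longer chain rather than an exchange of the chain for dimethylamino, so it bears on this change only loosely. The direction for compound 3 is therefore open, and the expected step of a number 9 percentage points higher from compound 2 to compound 3 (within the scatter) is small and uncertain. Compound 3 is estimated at 70%, within 35% to 95%.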

Compound 3, a percentage reported as inhibition, in the whole organism at one dose (the size of the read-out at that dose, not a potency): 100%
Estimate against measurement, compound 3: 30 percentage points below; the whole stated range lies below it.
By their numbers in this assay, from the lowest: compound 2; then compounds 1 and 3 (each within the scatter of the next).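

In this assay, the position takes a group other than a carbon chain without loss: exchanging butyl for dimethylamino gives a number 39 percentage points higher from compound 2 to compound 3 (beyond the scatter), and exchanging propyl for dimethylamino gives a number 7 percentage points higher from compound 1 to compound 3 (within the scatter). So the drop seen on lengthening the chain does not extend to every group at this aromatic carbon. Nothing available accounts for this result.

On these data alone, it remains open whether a smaller amine such as methylamino, or a cyclic amine such as morpholine, would hold up here. A single dose also leaves the potencies of compound 1 and compound 3 unresolved.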